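The source may report more compounds than this note shows. Statements on the series, on what has been measured and on what is new or still open speak of the compounds shown alone.

Compound 1 `C=Cc1ccc(S(=O)(=O)Nc2ccc(-c3nc4ccccc4o3)cc2)cc1` is a sulfonamide built on a shared core with a vinyl group on the outer aromatic ring. In an assay on cells for inhibition of HSP60/HSP10 (Homo sapiens), with a stated time of 60 min (a lower number here means a stronger inhibitor, a higher number a weaker inhibitor), compound 1 gives only > 100000 nM, which is a limit of the assay rather than a measured number. Its closest measured relative is compound 2 `O=S(=O)(Nc1ccc(-c2nc3ccccc3o2)cc1)c1ccc(C(F)(F)F)cc1`, which in this assay gives 50000 nM. That step, an at least 2.0-fold lower number from compound 1 to compound 2 (0.30 log units; that floor lies within the scatter), is the only one measured here, and it is an at least step because compound 1 sits at the limit of > 100000 nM in this assay, at which 2 of the 3 values shown sit. Compound 3 `COc1ccccc1S(=O)(=O)Nc1ccc2oc(-c3ccccc3)nc2c1` also gives a limit in this assay, namely > 100000 nM. The unmeasured compound 4 `O=S(=O)(Nc1ccc(-c2nc3ccccc3o2)cc1)c1ccc(Cl)c(Cl)c1` differs from compound 1 by 3,4-dichlorophenyl in place of 4-vinylphenyl on a sulfonyl sulfur. Going by the values given here, no measured step follows this exact change, so the expectation leans on compound 2, whose value 50000 nM shows that swapping the vinyl for another group can bring the number down at least modestly. Compound 4 is therefore expected to move by about an at least 2.0-fold lower number from compound 1 to compound 4 (0.30 log units; that floor lies within the scatter), giving an estimated 50000 nM, with a range from 15000 nM to 200000 nM.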

Compound 4, half-maximal inhibitory concentration: 25000 nM
Compound 4: middle estimate off by 2.0-fold (0.30 log units), on the high side; low and high end bracket the measured number.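

Replacing 4-vinylphenyl with 3,4-dichlorophenyl on the sulfonyl sulfur gives an at least 4.0-fold lower number from compound 1 to compound 4 (0.60 log units; beyond the scatter) in this assay, so a change at this position alone can move the number beyond the scatter, which the earlier step with trifluoromethyl could not show. Compound 2 gives 50000 nM and compound 4 gives 25000 nM; these values lie within the usual scatter of each other, so they do not rank the two groups. The step from compound 1 is only a floor, and its true size stays unknown, because compound 1 sits at a limit: the limit of > 100000 nM in this assay, at which 2 of the 4 values shown sit.

It remains open whether both chlorines are needed, since no ring with a single chlorine is among the compounds shown. Going by these compounds, how an amine or a carboxylic acid on this outer ring would affect the number also remains unknown.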